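Chloro to methyl: cytotoxicity notes on compound 3

This account rests on a few compounds, and the source may have more. Where it says the series, first, only, none or still open, it means among the compounds named here.

Among the compounds with values here, in an ADME assay on MT4 cells (Homo sapiens) for cytotoxicity, read by MTT assay (on this read-out higher numbers stand for lower toxicity in this test and lower numbers for higher toxicity in this test), compound 2 `O=C1c2ccccc2C(=O)N1CCOC(=S)N(C(=O)c1ccc(F)cc1F)c1ccc(Cl)cc1` gives 52000 nM, the only true number so far. Compound 1 `Cc1ccc(N(C(=O)c2ccccc2C)C(=S)OCCN2C(=O)c3ccccc3C2=O)cc1` reads > 100000 nM in this assay, and this value is a limit of the assay, not a number.

Compound 3 `Cc1ccc(N(C(=O)c2ccc(F)cc2F)C(=S)OCCN2C(=O)c3ccccc3C2=O)cc1` differs from compound 2 in one place, with methyl in place of chloro on an aromatic carbon, para to a large group, so 4-chlorophenyl becomes 4-methylphenyl (methyl in place of chloro on an aromatic carbon). Within the data shown here, no measured step in this assay isolates this swap, so only a small move toward higher numbers is expected, possibly none beyond the scatter. That expectation rests on compound 2 at 52000 nM as the sole numeric reference. The expected step of a 1.3-fold higher number from compound 2 to compound 3 (0.13 log units; within the scatter) is estimated as modest. For compound 3 the estimated value is 70000 nM, with an expected range of 32000 nM to 100000 nM for the measurement.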

Compound 3, half-maximal cytotoxic concentration: 20000 nM
For compound 3 the middle estimate is 3.5-fold (0.54 log units) above the measured one; the measured number lies below the stated range.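

In this assay, the change from 4-chlorophenyl to 4-methylphenyl now has a one-place measurement, and it moves toward higher toxicity in this test: a 2.6-fold lower number from compound 2 to compound 3 (0.41 log units; beyond the scatter). With 4-methylphenyl held constant, 2,4-difluorophenyl in place of 2-methylphenyl on the carbonyl carbon gives an at least 5.0-fold lower number from compound 1 to compound 3 (0.69 log units; beyond the scatter). That second step is only a bound because compound 1 stands at a limit of the assay, not a number: the limit of > 100000 nM in this assay, at which 1 of the 3 values shown sits.

A single swap cannot show whether the shift is specific to methyl or would also appear with methoxy or an amine on this aromatic carbon. From the compounds shown here alone, the true size of the step from 2-methylphenyl to 2,4-difluorophenyl remains open, as does whether the chloro-to-methyl step would hold with 2-methylphenyl on the carbonyl carbon.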